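The compounds below may be only part of what the source reports. "The series", "measured", "known", "first", "only" and "open" are said of these compounds alone.

Of the compounds shown here, three sharing one core have been measured in a functional assay on SF-295 cells (Homo sapiens) for inhibition, read by sulforhodamine B assay, with a stated time of 48 h; on this read-out higher numbers stand for lower toxicity in this test and lower numbers for higher toxicity in this test. Compound 1 `O=C(Nc1cccc(-n2cc(-c3ccncc3)c(-c3ccc(Cl)c(O)c3)n2)c1)Nc1cccc(C(F)(F)F)c1` gives 29200 nM; compound 2 `COc1cc(-c2nn(-c3cccc(NC(=O)Nc4cc(C(F)(F)F)cc(C(F)(F)F)c4)c3)cc2-c2ccncc2)ccc1Cl` gives 3310 nM; compound 3 `COc1cc(-c2nn(-c3cccc(NC(=O)Nc4cccc(C(F)(F)F)c4)c3)cc2-c2ccncc2)ccc1Cl` gives 3200 nM. Compound 3 carries the lowest number of the three, but the step of a 1.0-fold lower number from compound 2 to compound 3 (0.01 log units; within the scatter) stays within the scatter, whereas the step of a 9.1-fold lower number from compound 1 to compound 3 (0.96 log units; beyond the scatter) lies beyond it. Compound 4 `COc1cc(-c2nn(-c3cccc(NC(=O)c4ccccc4)c3)cc2-c2ccncc2)ccc1Cl` differs from compound 3 by phenyl in place of (3-(trifluoromethyl)phenyl)amino on a carbonyl carbon. Of the measured steps only a 1.0-fold lower number from compound 2 to compound 3 (0.01 log units; within the scatter) touches this part of the molecule, and there the exchange of a trifluoromethyl on an aromatic carbon for hydrogen left the number within the scatter. For the measured compounds named here, no measured pair tests the loss of the amino part of the leaving group, so that half of the change has no precedent here. The step is therefore expected to be small to modest, if anything towards a higher number, estimated at a 1.9-fold higher number from compound 3 to compound 4 (0.27 log units; within the scatter). Compound 4 is accordingly expected to give about 6000 nM, within a range of 2000 nM to 25000 nM.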

Compound 4, concentration lethal to 50% of the cells: > 100000 nM
Compound 4 ended at the assay's limit; the forecaster's own chance of this, stated with the estimate: 10%; middle value at least 16-fold (1.22 log units) away from the limit.
By their numbers in this assay, from the lowest: compounds 3 and 2 (each within the scatter of the next); then compound 1. At a limit, above all of these: compound 4.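

The change of (3-(trifluoromethyl)phenyl)amino to phenyl on a carbonyl carbon gives an at least 31-fold higher number from compound 3 to compound 4 (1.49 log units; beyond the scatter) and so shows that the number responds strongly to this end of the molecule. The earlier compounds had not shown this, since the only step touching this part, a 1.0-fold lower number from compound 2 to compound 3 (0.01 log units; within the scatter), stayed within the scatter when a trifluoromethyl gave way to hydrogen. In this assay compound 4 gives > 100000 nM and this is a limit of the assay, not a number: the limit of > 100000 nM in this assay, at which 1 of the 4 values shown sits.

The change removes the amino part and the remaining trifluoromethyl together, so the compounds shown leave open which of the two accounts for the step. On these data alone, a phenylamino group on the same carbonyl carbon would separate the two, and a benzyl group or a methylamino group there remains open as well.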